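The source may report more compounds than this note shows. Statements on the series, on what has been measured and on what is new or still open speak of the compounds shown alone.

Of the compounds shown here, three built on one shared core have been measured in a functional assay on IGROV-1 cells (Homo sapiens) for cytotoxicity, read by sulforhodamine B assay, with a stated time of 48 h; a lower number here means a stronger inhibitor of growth, a higher number a weaker inhibitor of growth. Compound 1 `CC1=C(C(=O)Nc2ccc(F)c(Cl)c2)C(c2ccccc2Cl)NC(=S)N1` gives 17800 nM. Compound 2 `CC1=C(C(=O)Nc2ccc(Cl)c(Cl)c2)C(c2ccccc2Cl)NC(=S)N1` gives 15800 nM, and compound 3 `COc1cccc(C2NC(=S)NC(C)=C2C(=O)Nc2ccc(Cl)c(Cl)c2)c1` gives 15800 nM. Compound 1 differs from compound 2 by fluoro in place of chloro on an aromatic carbon, and that change brought a 1.1-fold higher number from compound 2 to compound 1 (0.05 log units; within the scatter). The core of compound 3 differs from that of compound 2 by 3-methoxyphenyl in place of 2-chlorophenyl on a saturated ring carbon, a change that brought no change at the digits printed from compound 2 to compound 3 (within the scatter). All three numbers therefore lie within the usual scatter of one another, and none can be called stronger or weaker than the rest.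

Compound 4 `COc1cccc(C2NC(=S)NC(C)=C2C(=O)Nc2ccc(F)c(Cl)c2)c1` has not yet been measured in this assay. It differs from compound 3 by fluoro in place of chloro on an aromatic carbon; this is the same change that separates compound 2 from compound 1, made here on the core of compound 3, and it occurs twice among these compounds. Compound 4 is expected to show a step of a 1.1-fold higher number from compound 3 to compound 4 (0.03 log units; within the scatter), because the same change earlier gave a 1.1-fold higher number from compound 2 to compound 1 (0.05 log units; within the scatter). That expectation rests on a single measured pair. Compound 4 is therefore estimated at 17000 nM, with a likely range from 8000 nM to 36000 nM.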

Compound 4, concentration for 50% growth inhibition: 27500 nM
Compound 4: the middle estimate sits 1.6-fold (0.21 log units) below what was measured, and the stated range covers the measured number.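

In this assay, fluoro in place of chloro gave a 1.7-fold higher number from compound 3 to compound 4 (0.24 log units; within the scatter), and this step agrees with the earlier step for the same change: the same change on two cores in this assay, a 1.1-fold higher number (0.05 log units; within the scatter) from compound 2 to compound 1 and a 1.7-fold higher number (0.24 log units; within the scatter) from compound 3 to compound 4, 1.5-fold (0.19 log units) apart, within the scatter of two such steps. The change from 2-chlorophenyl to 3-methoxyphenyl gave a 1.5-fold higher number from compound 1 to compound 4 (0.19 log units; within the scatter), and it agrees in the same way with its earlier step: the same change on two cores in this assay, no change at the digits printed (within the scatter) from compound 2 to compound 3 and a 1.5-fold higher number (0.19 log units; within the scatter) from compound 1 to compound 4, 1.5-fold (0.19 log units) apart, within the scatter of two such steps. Both changes thus carried from one core to the other without a difference that stands out from the scatter, but since every step here also lies within the scatter, this does not show that a change with a clear effect would carry over, and two cores are a narrow basis for any such rule.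

The compounds shown leave open whether an amine or a carboxylic acid on the phenyl ring that carries the chloro group would move the number beyond the scatter. The same question stands for a longer chain in place of the methyl group on the shared core.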